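A Hydroxy Group on the Saturated Ring of Compound 3

The source may report more compounds than this note shows. Statements on the series, on what has been measured and on what is new or still open speak of the compounds shown alone.

Three compounds have been measured in an assay on isolated protein for binding affinity to Indoleamine 2,3-dioxygenase 1 (Homo sapiens), read by thermal shift assay, tested at 5 uM; on this read-out higher numbers stand for stronger stabilisation of the target against heat and lower numbers for weaker stabilisation of the target:
compound 1 `O=C(Nc1ccc(F)c(Cl)c1)C(=O)N1CCC(c2ccccc2)CC1` gives 1 degrees C
compound 2 `O=C(Nc1ccc(Cl)cc1)C(=O)N1CCC(c2ccccc2)CC1` gives 12 degrees C
compound 3 `O=C(Nc1ccc(Cl)cc1)C(=O)N1CCC(c2ccnc3ccc(F)cc23)CC1` gives 14 degrees C

Compound 3 stands highest of the three in this assay; compound 2 lies closest to it and compound 1 furthest away. Compound 4 `O=C(Nc1ccc(Cl)cc1)C(=O)N1CC[C@H](c2ccnc3ccc(F)cc23)[C@@H](O)C1` differs from compound 3 by hydroxy in place of hydrogen on a saturated ring carbon. Among the compounds with values here, the only measured step, a number 11 degrees C higher from compound 1 to compound 2 (beyond the scatter), concerns a change on the amide-type nitrogen and does not touch the saturated ring, so no measured step bears directly on this change. With nothing comparable to go on, the expected step of a number 1.0 degrees C lower from compound 3 to compound 4 (within the scatter) in this assay is small or none beyond the scatter. Compound 4 is therefore expected to give 13 degrees C, estimated between 8 degrees C and 17 degrees C.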

Compound 4, shift of the target's melting temperature: 13 degrees C
Compound 4: middle estimate and measured number agree at the digits printed; measured number inside the range.
By their numbers in this assay, from the lowest: compound 1; then compounds 2, 4 and 3 (each within the scatter of the next, the first and the last beyond it).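

Putting hydroxy in place of hydrogen on this saturated ring carbon gives a number 1.0 degrees C lower from compound 3 to compound 4 (within the scatter) in this assay. Within the data shown here, the earlier compounds all carry only hydrogen here, so this is the first sign that this carbon, next to the ring atom that bears a large group, can hold an added oxygen with no change beyond the scatter. Nothing available explains this result. Going by these compounds, whether an amine, a methoxy group or a longer chain on the same carbon would also leave the number within the scatter stays open.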